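The compounds below may be only part of what the source reports. "The series", "measured", "known", "first", "only" and "open" are said of these compounds alone.

Within the data shown here, compound 2 `C[C@@H]1CC/C(=N\Nc2ccc(O)cc2)c2ncc(C(=O)O)c(=O)n21` stands at the lowest of the two numbers so far: in a functional assay on the whole organism for inhibition, with Rattus norvegicus as the target (on this read-out lower numbers stand for an effect already at smaller amounts and higher numbers for an effect only at larger amounts of compound), compound 2 gives 0.14 umol/kg. Among the measured compounds shown here, its nearest neighbour is compound 1 `CC1CC/C(=N\Nc2ccc(O)cc2)c2ncc(C(=O)O)c(=O)n21`, which in this assay gives 1.7 umol/kg; the only measured step runs a 12-fold lower number from compound 1 to compound 2 (1.08 log units; beyond the scatter), and that step concerns the fact that one of compounds 1 and 2 is drawn with a defined configuration and the other without, at the place where they differ rather than any change of substituent.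

Compound 3 `CCOc1ccc(N/N=C2\CC[C@@H](C)n3c2ncc(C(=O)O)c3=O)cc1` has not been measured in this assay. It differs from compound 2 by ethyl in place of hydrogen on an oxygen on an aromatic ring. For the measured compounds named here, no measured step touches this oxygen; the one step in hand bears on a stereocentre and says nothing about ethyl in place of hydrogen on an oxygen on an aromatic ring. Going by the values given here, the expectation therefore rests on no measured precedent and is kept wide. Compound 3 is expected to give 0.3 umol/kg in this assay, within 0.07 umol/kg to 1.5 umol/kg. The step this means, a 2.1-fold higher number from compound 2 to compound 3 (0.33 log units; beyond the scatter), is expected to stay near the scatter.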

Compound 3, dose for 50% inhibition: 0.2 umol/kg
The estimate for compound 3 lay 1.5-fold (0.18 log units) above the measured number; measured number inside the range.
By their numbers in this assay, from the lowest: compounds 2 and 3 (each within the scatter of the next); then compound 1.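

In this assay, among these compounds, the first change at the oxygen on the aromatic ring, hydroxy to ethoxy, stays within the scatter: a 1.4-fold higher number from compound 2 to compound 3 (0.15 log units; within the scatter). For this pair, the hydrogen on that oxygen can therefore be replaced by ethyl with no change in the read-out that can be told from the scatter, while the stereocentre stays as drawn. Nothing in hand gives a cause for this result at the oxygen.

The compounds shown leave open whether the same holds for other groups on this oxygen, such as methyl or a longer chain like butyl, or for an amine in place of the hydroxy. Also open, from the compounds shown here alone, is whether the stereocentre matters as much with ethoxy as with hydroxy, where the step reads: a 12-fold lower number from compound 1 to compound 2 (1.08 log units; beyond the scatter).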